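Urea series: aryl group swap on the amide nitrogen

The source may hold more compounds than are shown below. What is called first, only, known or untested is meant among the compounds shown, and "the series" means these compounds.

Compound 1 `Cc1cc(C)c(NC(=O)N(Cc2ccccc2)Cc2cccc(-c3cc[nH]n3)c2)c(C)c1`: > 1 mg/kg
Compound 2 `O=C(Nc1c(F)cc(F)cc1F)N(Cc1ccccc1)Cc1cccc(-c2cc[nH]n2)c1`: 0.096 mg/kg
Compound 3 `CSc1cc(C)nc(SC)c1NC(=O)N(Cc1ccccc1)Cc1cccc(-c2cc[nH]n2)c1`: not yet measured

In a functional assay on a cell-free system (plasma) with sterol O-acyltransferase, Soat (Rattus norvegicus) as the target (a higher number here means that more compound is needed for the effect, a lower number that less compound is needed), compound 1 gives > 1 mg/kg, which is a limit of the assay (the limit of > 1 mg/kg in this assay, at which 1 of the 2 values shown sits). In this assay compound 2 gives 0.096 mg/kg, the only number shown so far. Among the measured compounds shown here, the one measured step, an at least 10-fold lower number from compound 1 to compound 2 (1.01 log units; beyond the scatter), sits at the same position as the change to compound 3, namely (a group of 11 heavy atoms (8 carbon, 1 nitrogen, 2 sulfur; one six-membered aromatic ring with 1 hetero atom) in place of a group of 9 heavy atoms (6 carbon, 3 fluorine; one six-membered aromatic ring of carbon only), on an amide-type nitrogen), but neither group of that step reappears here. Compound 3 is therefore expected to land somewhere between the two, estimated at 0.5 mg/kg (range 0.1 mg/kg to 3 mg/kg), an expected step of a 5.2-fold higher number from compound 2 to compound 3 (0.72 log units; beyond the scatter) with a fair chance of only a limit.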

Compound 3, dose for half-maximal effect: 0.046 mg/kg
The estimate for compound 3 lay 11-fold (1.04 log units) above the measured number, outside the stated range (below it).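

In this assay the place on the amide-type nitrogen is not tied to a ring of carbon only: the group with a six-membered aromatic ring with 1 hetero atom brings a 2.1-fold lower number from compound 2 to compound 3 (0.32 log units; beyond the scatter) in place of 2,4,6-trifluorophenyl. The same group brings an at least 21-fold lower number from compound 1 to compound 3 (1.33 log units; beyond the scatter) in place of 2,4,6-trimethylphenyl. The value of compound 1 in that comparison is a limit: the limit of > 1 mg/kg in this assay, at which 1 of the 3 values shown sits.

Going by these compounds, what a morpholine or a carboxylic acid on the ring at this place would give stays open, as does any change elsewhere on the shared core.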